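This account rests on a few compounds, and the source may have more. Where it says the series, first, only, none or still open, it means among the compounds named here.

Measured compounds in an in vitro ADME assay on microsomes from liver (Homo sapiens) for metabolic stability; on this read-out lower numbers stand for a shorter-lived compound and higher numbers for a longer-lived compound:
- compound 1, `CS(=O)(=O)Nc1ccc2c(c1)S(=O)(=O)N=C(C1=C(O)C3CCCC3N(CCC3CC3)C1=O)N2`: 0.417 h
- compound 2, `CS(=O)(=O)Nc1ccc2c(c1)S(=O)(=O)N=C(c1c(O)c3cccn3n(Cc3ccc(F)cc3)c1=O)N2`: > 1 h

For the measured compounds named here, of the two values shown for this assay, compound 1 carries the only number. The value of compound 2 is a limit of the assay and not a number (the limit of > 1 h in this assay, at which 1 of the 2 values shown sits). Going by the values given here, no pair of measured compounds differs in a single place, so no measured step is available as a yardstick.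

Compound 3, `CS(=O)(=O)Nc1ccc2c(c1)S(=O)(=O)N=C(C1=C(O)C3CCCC3N(Cc3ccccn3)C1=O)N2`, is not yet measured. It departs from compound 1 by one change: pyridin-2-yl in place of cyclopropylmethyl on a saturated chain carbon bound to an amide-type nitrogen in a ring. The cyclopropylmethyl of compound 1 gives way to pyridin-2-yl on the saturated chain carbon bound to the amide-type nitrogen in the ring, so that 2-cyclopropylethyl becomes (pyridin-2-yl)methyl.

Among the compounds with values here, with no measured step to lean on, no shift beyond the usual scatter is expected from this change in this assay; the expectation is that the step from compound 1 to compound 3 amounts to a 1.2-fold higher number from compound 1 to compound 3 (0.08 log units; within the scatter). For compound 3 the estimate in this assay is 0.5 h, with a range from 0.2 h to 1.2 h, where the upper end allows the assay to report only a limit.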

Compound 3, half-life: > 1 h
Compound 3: a limit, no number (the forecaster's own chance of this, stated with the estimate: 20%); middle value at least 2.0-fold (0.30 log units) away from the limit.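

In this assay, for the compounds shown here, the exchange of cyclopropylmethyl for pyridin-2-yl gives the first measured step at this position, an at least 2.3-fold higher number from compound 1 to compound 3 (0.37 log units; beyond the scatter), so the group on the saturated chain carbon bound to an amide-type nitrogen in a ring does bear on this read-out. The value of compound 3 is a limit of the assay and not a number, so the printed step gives only a floor for the size of the change: the limit of > 1 h in this assay, at which 2 of the 3 values shown sit. The exchange replaces a three-membered non-aromatic ring of carbon only with a six-membered aromatic ring with 1 hetero atom, and this single pair cannot show which of these differences carries the step.

Open, on these data alone, is how phenyl, pyridin-3-yl or a longer alkyl chain would read at this place on the shared core, which would separate the share of the ring nitrogen from that of the aromatic ring. As far as these compounds go, compound 2 differs from compound 1 in more than one place, so it offers no comparison for this change, and the size of the step beyond the limit remains unknown.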